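The compounds below may be only part of what the source reports. "The series", "measured", "known", "first", "only" and "open" are said of these compounds alone.

Series notes. Three measured compounds share a core and differ in the aryl group on the saturated chain carbon bound to the ring nitrogen. In an ADME assay on Vero cells (Chlorocebus sabaeus) for cytotoxicity, read by MTT assay, with a stated time of 48 h (on this read-out higher numbers stand for weaker inhibition and lower numbers for stronger inhibition), compound 1 `COc1ccc(CNc2nc(=O)c3cc(C(F)(F)F)cc([N+](=O)[O-])c3o2)cc1OC` gives 29.2 ug/mL. Compound 3 `O=c1nc(NCc2ccc3c(c2)OCCO3)oc2c([N+](=O)[O-])cc(C(F)(F)F)cc12` gives 25.3 ug/mL in this assay, the lowest of the two numbers measured, though its nearest neighbour is compound 1 and that gap lies within the scatter. Compound 2 `O=c1cc(NCc2cccc(F)c2)sc2c([N+](=O)[O-])cc(C(F)(F)F)cc12`, on a different core, gives in this assay only a limit of the assay, > 64 ug/mL. Among the measured compounds shown here, the one measured step is a 1.2-fold lower number from compound 1 to compound 3 (0.06 log units; within the scatter), an exchange of two dialkoxy-substituted aryl groups, and it did not move the number beyond the scatter. The limit of > 64 ug/mL in this assay, at which 1 of the 3 values shown sits, marks where one of the three values sits.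

Compound 4 `O=c1nc(NCc2ccc(F)cc2)oc2c([N+](=O)[O-])cc(C(F)(F)F)cc12` differs from compound 3 by 4-fluorophenyl in place of 2,3-dihydro-1,4-benzodioxin-6-yl on a saturated chain carbon bound to a nitrogen on an aromatic ring. For the measured compounds named here, no measured step covers a swap of the 2,3-dihydro-1,4-benzodioxin-6-yl group for a 4-fluorophenyl group on this core; compound 2, the only fluorophenyl-bearing compound, sits on another core and its value is a limit, so it supplies no step. With nothing to build on, the expected step is a 1.1-fold higher number from compound 3 to compound 4 (0.04 log units; within the scatter), that is, none beyond the scatter. Compound 4 is estimated at 28 ug/mL in this assay, with a range from 12 ug/mL to 64 ug/mL.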

Compound 4, half-maximal inhibitory concentration: > 64 ug/mL
Compound 4 gave a limit, no number; the forecaster's own chance of this, stated with the estimate: 25%; middle value at least 2.2-fold (0.35 log units) away from the limit.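

At this position, on a saturated chain carbon bound to a nitrogen on an aromatic ring, the choice of aryl group does change the reading in this assay. The exchange between the two dialkoxy-substituted groups stayed within the scatter, whereas 4-fluorophenyl gives an at least 2.5-fold higher number from compound 3 to compound 4 (0.40 log units; beyond the scatter) and an at least 2.1-fold higher number from compound 1 to compound 4 (0.34 log units; beyond the scatter). Both steps are lower bounds, and only their direction and their place beyond the scatter are firm, as compound 4 gave a limit and not a number: the limit of > 64 ug/mL in this assay, at which 2 of the 4 values shown sit.

The compounds shown leave open how far the number would rise for compound 4, and whether the step follows the entering fluorine or the leaving oxygen atoms, as the 4-fluorophenyl group differs from both earlier groups in both respects. A plain phenyl group and a 4-methoxyphenyl group at this same place would separate those two readings, and a pyridyl ring or a cyclohexyl group would show whether an aromatic carbon ring is needed at all for the lower numbers of compound 1 and compound 3.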